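Notes on benzyl ring changes, compounds 1 to 4

This account rests on a few compounds, and the source may have more. Where it says the series, first, only, none or still open, it means among the compounds named here.

Measured so far in a functional assay on MCF7 cells (Homo sapiens) for cytotoxicity, read by MTT assay, with a stated time of 72 h; a lower number here means a stronger inhibitor, a higher number a weaker inhibitor:
compound 1, `Cc1cc(-c2ccccc2)n(/C(N)=N/S(=O)(=O)c2cc(C)c(Cl)cc2SCc2ccccc2C(F)(F)F)n1`: 101000 nM
compound 2, `Cc1cccc(CSc2cc(Cl)c(C)cc2S(=O)(=O)/N=C(\N)n2nccc2-c2ccccc2)c1`: 47000 nM
compound 3, `Cc1cc(-c2ccccc2)n(/C(N)=N/S(=O)(=O)c2cc(C)c(Cl)cc2SCc2cccc3ccccc23)n1`: 170000 nM

Compound 2 holds the lowest number of the three in this assay; compound 1 is nearest to it, compound 3 furthest, and both gaps are beyond the scatter. Among the measured compounds shown here, the only single-point step among the measured compounds is on the benzyl ring bound to sulfur: a 1.7-fold higher number from compound 1 to compound 3 (0.23 log units; within the scatter). For the measured compounds named here, that step is within the scatter, so the one comparison available on this part of the structure shows no change in this assay that can be trusted.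

Compound 4, `Cc1cc(S(=O)(=O)/N=C(\N)n2nccc2-c2ccccc2)c(SCc2cccc(Cl)c2)cc1Cl`, is not yet measured. It differs from compound 2 as follows: chloro in place of methyl on an aromatic carbon. Going by the values given here, the change sits on the same benzyl ring that was varied between compound 1 and compound 3, where the step in this assay stayed within the scatter; no measured step shows what chloro in place of methyl does here. The expectation for compound 4 is therefore a step of about a 1.1-fold higher number from compound 2 to compound 4 (0.03 log units; within the scatter), none beyond the scatter, in this assay. Compound 4 is estimated at 50000 nM, with a range from 20000 nM to 125000 nM.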

Compound 4, half-maximal inhibitory concentration: 88000 nM
Estimate against measurement, compound 4: 1.8-fold (0.25 log units) below; low and high end bracket the measured number.
By their numbers in this assay, from the lowest: compounds 2, 4, 1 and 3 (each within the scatter of the next, the first and the last beyond it).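

In this assay, among the compounds shown here, chloro in place of methyl on the benzyl ring gives a 1.9-fold higher number from compound 2 to compound 4 (0.27 log units; within the scatter), the first measured step for a change at this place, where 3-methylbenzyl becomes 3-chlorobenzyl. The benzyl ring now has two single-place steps, this one and a 1.7-fold higher number from compound 1 to compound 3 (0.23 log units; within the scatter), and neither can be told apart from repeat scatter, although they involve different groups on different cores, so they do not establish a rule for the ring as a whole. No supporting measurement accompanies this step, so the data offer no explanation for it.

Still open, on these data alone, is whether a group of another kind at this place, such as an amine, a hydroxyl or a carboxylic acid, would give a step beyond the scatter in this assay. Also open, as far as these compounds go, is whether chloro in place of methyl gives a similar step on the core of compound 1 or elsewhere on the benzyl ring.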